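A few compounds are considered here, and "the series" means these few. Any claim that something is new, unique, unknown or untested is made for them only; others in the source may bear on it.

Two compounds share one core and differ only in the group on an amide-type nitrogen. Compound 1 `O=C(CN1CCC(c2cccc[n+]2[O-])CC1)Nc1ccc(F)cc1F` carries a 2,4-difluorophenyl there, and in a functional assay on HEK293 cells for agonist activity at D(4) dopamine receptor (Homo sapiens), read by FLIPR (a higher number here means a larger maximal response, a lower number a smaller maximal response), compound 1 gives 74%. Going by the values given here, compound 2 `O=C(CN1CCC(c2cccc[n+]2[O-])CC1)NC1CCCCC1` carries a cyclohexyl instead, and in this assay compound 2 gives 58%, the lower of the two numbers; the only measured step, a number 16 percentage points lower from compound 1 to compound 2 (beyond the scatter), is beyond the scatter and modest. Compound 3 `Cc1cc(F)ccc1NC(=O)CN1CCC(c2cccc[n+]2[O-])CC1` has not yet been measured. It differs from compound 2 in one place: 4-fluoro-2-methylphenyl in place of cyclohexyl on an amide-type nitrogen. Among the compounds with values here, this largely reverses the earlier change, bringing back an aromatic ring of carbon only, so the step from compound 1 to compound 2 is the one guide, and a rise of roughly that size is expected in this assay, a number 12 percentage points higher from compound 2 to compound 3 (beyond the scatter). Compound 3 is therefore expected to reach about 70%, within a range from 58% to 82%.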

Compound 3, largest response reached (reported as efficacy), in percent of the reference or control that the assay uses: 84%
Compound 3: middle estimate off by 14 percentage points, on the low side; measured number above the stated range.
By their numbers in this assay, from the lowest: compound 2; then compounds 1 and 3 (each within the scatter of the next).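

In this assay the change from cyclohexyl to 4-fluoro-2-methylphenyl gives a number 26 percentage points higher from compound 2 to compound 3 (beyond the scatter) and so supplies a second case of a ring of aromatic carbon on the amide-type nitrogen reading above the cyclohexyl of compound 2, with no compound shown going against this. The two aromatic groups cannot be told apart, since methyl in place of fluoro on an aromatic carbon gives a number 10 percentage points higher from compound 1 to compound 3 (within the scatter) and this small change leaves the response within the usual variation. No data here bear on what lies behind these differences.

With only three groups shown, it remains open whether the response depends on an aromatic ring as such. A plain phenyl, a pyridine ring or an open butyl chain on that nitrogen could help to settle this.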